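The source may report more compounds than this note shows. Statements on the series, on what has been measured and on what is new or still open speak of the compounds shown alone.

In a functional assay on A549 cells (Homo sapiens) for antiproliferative activity, read by sulforhodamine B assay, with a stated time of 48 h (a lower number here means a stronger inhibitor, a higher number a weaker inhibitor), three related compounds have been measured so far. Compound 1 `COc1cc(C(=O)/C=C\Nc2ccc(-c3nc4cc(OC)c(OC)c(OC)c4s3)cc2)c(Br)c(OC)c1OC` gives 13600 nM, the highest number of the three and so the weakest result. The nearest neighbour is compound 3 `COc1ccc2nc(-c3ccc(N/C=C\C(=O)c4cc(OC)c(OC)c(OC)c4Br)c(C)c3)sc2c1` at 6400 nM, and furthest away lies compound 2 `COc1ccc2nc(-c3ccc(N/C=C\C(=O)c4ccc(OC)c(F)c4)cc3)sc2c1` at 900 nM. Both gaps from compound 1 are beyond the usual scatter.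

The next molecule is compound 4 `COc1cc(OC)c2sc(-c3ccc(N/C=C\C(=O)c4cc(OC)c(OC)c(OC)c4Br)cc3)nc2c1`, which has hydrogen in place of methoxy on an aromatic carbon of the core of compound 1: hydrogen in place of methoxy on an aromatic carbon. Among the compounds with values here, no two measured compounds differ in one place only, so the data do not show directly what this single change does in this assay. The closest clue is indirect. Compound 3, at 6400 nM, also carries fewer methoxy groups on that part of the molecule than compound 1, but it differs in other places too, so it offers only weak guidance.

A moderate move towards a lower number is therefore expected, with the estimated change being a 2.1-fold lower number from compound 1 to compound 4 (0.32 log units; beyond the scatter). For compound 4 the expected value is 6500 nM, with an estimated range from 2000 nM to 20000 nM.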

Compound 4, half-maximal inhibitory concentration: 12000 nM
The estimate for compound 4 lay 1.8-fold (0.27 log units) below the measured number; low and high end bracket the measured number.
By their numbers in this assay, from the lowest: compound 2; then compounds 3, 4 and 1 (each within the scatter of the next, the first and the last beyond it).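

In this assay, within the data shown here, the first direct comparison at this position gives a 1.1-fold lower number from compound 1 to compound 4 (0.05 log units; within the scatter), so the two compounds cannot be told apart. On this aromatic carbon of the core, then, methoxy can give way to hydrogen without a difference that stands out from ordinary repeat measurements, and within this pair the methoxy group is not needed for the level of activity seen in compound 1. No measurement is available that would explain this result.

This single pair covers one swap on one carbon, with the two neighbouring methoxy groups of the place described kept in both compounds, so it cannot say whether hydrogen would be tolerated as well if those groups were also replaced or if other parts of the molecule were different. Also open, going by these compounds, is how a different group on this carbon, such as a hydroxyl group, an amine or a longer ether like ethoxy, would compare, as hydrogen and methoxy are the only two seen here.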